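Swapping the Amide Aryl Group Ahead of Compound 4

A few compounds are considered here, and "the series" means these few. Any claim that something is new, unique, unknown or untested is made for them only; others in the source may bear on it.

Three compounds have been measured in a functional assay on GTL 16 cells for antiproliferative activity against GTL 16 cell line (Homo sapiens), read by CCK-8 assay, with a stated time of 72 h; on this read-out higher numbers stand for weaker inhibition and lower numbers for stronger inhibition:

Compound 1, `COc1ccc(C(=O)Nc2cccc(-c3oc4cc(-c5ccc(F)cc5)ccc4c(=O)c3O)c2)cc1`, gives 21100 nM.
Compound 2, `O=C(Nc1cccc(-c2oc3cc(-c4ccc(F)cc4)ccc3c(=O)c2O)c1)c1ccc(Br)cc1`, gives 25400 nM.
Compound 3, `COc1cc(OC)cc(C(=O)Nc2cccc(-c3oc4cc(-c5ccc(F)cc5)ccc4c(=O)c3O)c2)c1`, gives 19600 nM.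

All three share one core and differ only in the aryl group attached to the carbonyl carbon of the amide. Going by the values given here, compound 3 shows the lowest of the three numbers, but its gaps to the others are small: a 1.1-fold lower number from compound 1 to compound 3 (0.03 log units; within the scatter) and a 1.3-fold lower number from compound 2 to compound 3 (0.11 log units; within the scatter), both within the scatter, so no compound can be called stronger than another on these data. The step from compound 1 to compound 2 is likewise small: a 1.2-fold higher number from compound 1 to compound 2 (0.08 log units; within the scatter).

Compound 4, `O=C(Nc1cccc(-c2oc3cc(-c4ccc(F)cc4)ccc3c(=O)c2O)c1)c1ccc([N+](=O)[O-])cc1`, has not yet been measured. It differs from compound 3 by 4-nitrophenyl in place of 3,5-dimethoxyphenyl on a carbonyl carbon. All three measured steps bear on this change, since each swaps the aryl group on the same carbonyl carbon, and none of them moved the number beyond the scatter. A further swap at the same place is therefore expected to leave this assay roughly where it stands, with no step beyond the scatter in either direction; the expected step is a 1.1-fold higher number from compound 3 to compound 4 (0.05 log units; within the scatter). Compound 4 is estimated at 22000 nM, with a range from 10000 nM to 48000 nM.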

Compound 4, half-maximal inhibitory concentration: 18200 nM
Compound 4: middle estimate off by 1.2-fold (0.08 log units), on the high side; the range from low to high includes it.
By their numbers in this assay, from the lowest: compounds 4, 3, 1 and 2 (each within the scatter of the next).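

In this assay the 4-nitrophenyl group extends the set of aryl groups on this carbonyl carbon, and replacing 3,5-dimethoxyphenyl with it gives a 1.1-fold lower number from compound 3 to compound 4 (0.03 log units; within the scatter) in a sentence of the same kind as every earlier swap here. Nitro in place of methoxy gives a 1.2-fold lower number from compound 1 to compound 4 (0.06 log units; within the scatter) while nitro in place of bromo gives a 1.4-fold lower number from compound 2 to compound 4 (0.14 log units; within the scatter) and this last step is the widest gap among the four compounds, yet even it stays within the scatter, so methoxy, bromo, nitro and the pair of methoxy groups cannot be told apart at this position on these data. No measurement in hand offers a reason for this sameness.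

As far as these compounds go, all four compounds keep an aryl ring on the carbonyl carbon, so it remains open whether an amine or a carboxylic acid on that ring, or a longer chain in place of the ring, would move the number beyond the scatter. The shared core is also the same throughout, which leaves open whether a change elsewhere in the molecule would shift this assay more than any swap at this position has.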